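This account rests on a few compounds, and the source may have more. Where it says the series, first, only, none or still open, it means among the compounds named here.

Two closely related large-ring compounds have been tested so far, and neither gives an exact reading. In a functional assay on 1A9/ptx-10 cells (Homo sapiens) for inhibition (a higher number here means a weaker inhibitor, a lower number a stronger inhibitor), compound 1, `COc1ccc2cc1Oc1ccc(cc1)/C=C\COC(=O)CC2`, gives > 2500 nM, which is a limit of the assay and not a number. Compound 2, `COc1ccc2cc1Oc1ccc(cc1)CC(I)COC(=O)CC2`, gives > 2500 nM, which is also a limit of the assay and not a number. The whole record so far is the limit of > 2500 nM in this assay, at which 2 of the 2 values shown sit, so compound 2 sits with compound 1 at that limit, and neither can be ranked against the other.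

Compound 3, `COc1ccc2cc1Oc1ccc(cc1)CC(O)COC(=O)CC2`, is the untested partner of compound 2. The change is hydroxy in place of iodo on a saturated ring carbon.

Within the data shown here, no measured step shows what such a swap does in this assay, so any forecast is cautious. No step beyond the usual scatter is expected in either direction, and another reading at the limit is the likeliest outcome. The estimated change is a step that the limit leaves unreadable from compound 2 to compound 3. For compound 3 the expected value is 3000 nM, with an estimated range from 1000 nM to 10000 nM.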

Compound 3, half-maximal inhibitory concentration: > 2500 nM
Compound 3 ended at the assay's limit; the forecaster's own chance of this, stated with the estimate: 75%; the middle value is on the limit's open side.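

Compound 2 and compound 3 both stand at a limit of this assay and not at a number, so no step can be read for hydroxy in place of iodo: the limit of > 2500 nM in this assay, at which 3 of the 3 values shown sit. From the compounds shown here alone, how strongly each of the three compounds inhibits, and whether hydroxy or iodo does better on that saturated ring carbon, remains open.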